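The source may hold more compounds than are shown below. What is called first, only, known or untested is meant among the compounds shown, and "the series" means these compounds.

Working notes on the series. Compound 1 `Cc1cc(S(=O)(=O)/N=C(\N)n2nccc2-c2ccccc2)c(SCc2ccccc2)cc1Cl` and compound 2 `Cc1cc(-c2ccccc2)n(/C(N)=N/S(=O)(=O)c2cc(C)c(Cl)cc2SCc2ccccc2C)n1` have been run in a functional assay on MCF7 cells (Homo sapiens) for cytotoxicity, read by MTT assay, with a stated time of 72 h; on this read-out higher numbers stand for weaker inhibition and lower numbers for stronger inhibition. Compound 1 gives 20000 nM. Compound 2 gives 80000 nM, the higher of the two numbers, and its gap to compound 1 lies beyond the scatter. Compound 3 `Cc1cc(S(=O)(=O)/N=C(\N)n2nccc2-c2ccccc2)c(SCc2ccccc2C)cc1Cl` is not yet measured. Relative to compound 2 it carries hydrogen in place of methyl on an aromatic carbon. Compound 3 is expected to move from compound 2 by a 2.7-fold lower number from compound 2 to compound 3 (0.43 log units; beyond the scatter), toward the number of compound 1, because compound 1 gives 20000 nM without that methyl. The estimate for compound 3 is 30000 nM, within 10000 nM to 100000 nM.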

Compound 3, half-maximal inhibitory concentration: 23000 nM
Estimate against measurement, compound 3: 1.3-fold (0.12 log units) above; the range from low to high includes it.
By their numbers in this assay, from the lowest: compounds 1 and 3 (each within the scatter of the next); then compound 2.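

Taken alone, the methyl on the five-membered aromatic ring with 2 nitrogen matters in this assay: removing it gives a 3.5-fold lower number from compound 2 to compound 3 (0.54 log units; beyond the scatter). The methyl change at the other aromatic carbon gives a 1.2-fold higher number from compound 1 to compound 3 (0.06 log units; within the scatter), so that step does not separate the pair, and the number of compound 2 goes with the methyl on the five-membered ring. No available measurement explains this step.

Open, from the compounds shown here alone, is how an ethyl group, an amine or a trifluoromethyl group would read at this carbon. Also open, going by these compounds, is whether the step holds without the second methyl.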